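Difluoromethoxy in Place of Chloro on Compound 3

The compounds below may be only part of what the source reports. "The series", "measured", "known", "first", "only" and "open" are said of these compounds alone.

In an assay on cells for inhibition of S-adenosylmethionine decarboxylase proenzyme (Homo sapiens), read by mass spectrometry, at pH 7.2 (on this read-out higher numbers stand for weaker inhibition and lower numbers for stronger inhibition), three compounds have been measured so far, and each returned only a limit of the assay rather than a number. Compound 1 `Nc1ccnc(Nc2cc(Cl)cc(Cl)c2)c1` gives > 180000 nM, a limit. Compound 2 `Cc1cc(Nc2cccc(Cl)c2)nc(N)n1` gives > 180000 nM, also a limit. Compound 3 `Cc1cc(Nc2cc(Cl)c(Cl)c(Cl)c2)nc(N)n1` gives > 63000 nM, again a limit. Compound 3 thus stands at the limit of > 63000 nM in this assay, at which 1 of the 3 values shown sits. Compounds 1 and 2 sit at the limit of > 180000 nM in this assay, at which 2 of the 3 values shown sit. No order among the three can be read from limits alone. Compound 4 `Cc1cc(Nc2cc(Cl)c(OC(F)F)c(Cl)c2)nc(N)n1` differs from compound 3 by difluoromethoxy in place of chloro on an aromatic carbon. Among the measured compounds shown here, with no measured step to draw on, a step that the limit leaves unreadable from compound 3 to compound 4 is expected in this assay, nothing beyond the scatter. Compound 4 is estimated at 120000 nM, with a range from 30000 nM to 500000 nM, and a further limit would not surprise.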

Compound 4, half-maximal inhibitory concentration: > 63000 nM
Compound 4: no number, only a limit; the forecaster's own chance of this, stated with the estimate: 75%; the middle value lies beyond the limit too.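

Compound 3 and compound 4 both return only limits, and the step between them, difluoromethoxy in place of chloro, cannot be read. The compounds shown leave open how any of them ranks against the others.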